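A few compounds are considered here, and "the series" means these few. Any claim that something is new, unique, unknown or untested is made for them only; others in the source may bear on it.

Three compounds built on the shared core of compound 1 `NC1=NC2(CCOCC2)N(OCCCOc2ccc(Cl)cc2Cl)C(N)=N1` have been examined in a functional assay on HCT-116 cells (Homo sapiens) for antiproliferative activity, read by MTT assay, with a stated time of 72 h; a lower number here means a stronger inhibitor, a higher number a weaker inhibitor. Compound 1 gives 880 nM. Among the compounds with values here, compound 2 `NC1=NC2(CCOCC2)N(OCCCOc2cccc(Br)c2)C(N)=N1` gives 40 nM, and the single change between them, 3-bromophenyl in place of 2,4-dichlorophenyl on an oxygen on a saturated carbon, produces a 22-fold lower number from compound 1 to compound 2 (1.34 log units; beyond the scatter). Compound 3 `CC(C)(C)c1ccc(OCCCON2C(N)=NC(N)=NC23CCOCC3)cc1` gives 1610 nM, the highest number of the three; its gap to compound 1 lies within the scatter, while its gap to compound 2 lies beyond it.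

Compound 4 `NC1=NC2(CCOCC2)N(OCCCOc2ccccc2)C(N)=N1` has not yet been measured in this assay. It differs from compound 3 in one place: hydrogen in place of tert-butyl on an aromatic carbon. Within the data shown here, no measured step touches a tert-butyl group, so the only guide is the step from compound 1 to compound 2, which shows that the pattern on this aromatic ring can shift the number by a large amount. Since compound 3 with its tert-butyl is the weakest-reading compound here and compound 2 the strongest, the unsubstituted ring of compound 4 is expected to land between them, with a 4.0-fold lower number from compound 3 to compound 4 (0.60 log units; beyond the scatter) as the anticipated movement. Compound 4 is therefore estimated at 400 nM, within a range from 100 nM to 1800 nM.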

Compound 4, half-maximal inhibitory concentration: 6010 nM
The estimate for compound 4 lay 15-fold (1.18 log units) below the measured number, outside the stated range (above it).
By their numbers in this assay, from the lowest: compound 2; then compounds 1 and 3 (each within the scatter of the next); then compound 4.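

The unsubstituted phenyl ring turns out to be the weakest of the four in this assay, so each of the three substituted rings shown reads lower than the bare ring, with no compound here going against that. Hydrogen in place of tert-butyl gives a 3.7-fold higher number from compound 3 to compound 4 (0.57 log units; beyond the scatter), and phenyl in place of 2,4-dichlorophenyl gives a 6.8-fold higher number from compound 1 to compound 4 (0.83 log units; beyond the scatter), both modest steps, whereas hydrogen in place of bromo gives a 150-fold higher number from compound 2 to compound 4 (2.18 log units; beyond the scatter), a large step that sets the 3-bromophenyl ring well apart from the other substituted rings. Substitution on this ring therefore matters in both its presence and its kind, but nothing available here explains why these groups differ in this way.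

The compounds shown leave open whether a single chloro group or a bromo group on another ring carbon would keep the low number of compound 2. They also leave open how an amine or a carboxylic acid on this ring would read, and whether a longer chain in place of the three-carbon link would change the ranking of these rings.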